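Stereo drawing at the chain carbon: compound 3 to compound 4

The source may report more compounds than this note shows. Statements on the series, on what has been measured and on what is new or still open speak of the compounds shown alone.

Values measured so far in a physicochemical assay for lipophilicity, read by HPLC, measured as octanol-water partition; a higher number here means a more lipophilic compound, a lower number a more polar compound
- compound 1 `COCCC(Oc1ncnc2c1cnn2-c1ccccc1Cl)C(=O)Nc1ccc(C)cn1` gives 4.1
- compound 2 `COCCC(Oc1ncnc2c1cnn2-c1ccccc1C)C(=O)Nc1ccc(C)cn1` gives 4.2
- compound 3 `COCC[C@H](Oc1ncnc2c1cnn2-c1ccccc1OC)C(=O)Nc1ccc(C)cn1` gives 3.5

Compound 3 has the lowest number of the three in this assay, and both compound 1 and compound 2 lie beyond the scatter from it. Compound 4 `COCCC(Oc1ncnc2c1cnn2-c1ccccc1OC)C(=O)Nc1ccc(C)cn1` is the next to be read. The change from compound 3 is the two compounds have the same atoms and bonds; at least one stereo element is drawn with a configuration in one of them and without one in the other: 1 of 1 stereo elements differ; a stereocentre at a saturated chain carbon is drawn S in compound 3 and without a configuration in compound 4. Nothing leaves and nothing enters: the only difference is that a stereocentre at a saturated chain carbon is drawn S in compound 3 and without a configuration in compound 4.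

The series holds one measured step, a number 0.10 log units higher from compound 1 to compound 2 (within the scatter). That step is methyl in place of chloro on an aromatic carbon, so it does not touch the stereocentre and gives no direct size for this change. Among the measured compounds shown here, no measured pair differs only in a drawn configuration. With atoms and bonds identical, the expectation rests on compound 3 at 3.5, and no step beyond the scatter is expected in this assay. The expected move is no change at the digits printed from compound 3 to compound 4 (within the scatter). For compound 4 the estimated value is 3.5, with an expected range of 3.2 to 3.8.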

Compound 4, distribution coefficient: 3.5
For compound 4 middle estimate and measured number coincide at the digits printed, within the range that was stated.
By their numbers in this assay, from the lowest: compounds 3 and 4 (each within the scatter of the next); then compounds 1 and 2 (each within the scatter of the next).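

In this assay the stereocentre at the saturated chain carbon gives no change at the digits printed from compound 3 to compound 4 (within the scatter), and this comparison rests on a single structural fact: the fact that one of compounds 3 and 4 is drawn with a defined configuration and the other without, at the place where they differ

Compound 4 carries the same undrawn configuration as compounds 1 and 2, so the aromatic group can now be compared in one place: methoxy in place of methyl gives a number 0.70 log units lower from compound 2 to compound 4 (beyond the scatter), and methoxy in place of chloro gives a number 0.60 log units lower from compound 1 to compound 4 (beyond the scatter). Among the compounds shown here, the earlier step of methyl in place of chloro, a number 0.10 log units higher from compound 1 to compound 2 (within the scatter), stayed within the scatter, and compound 3 differed from compounds 1 and 2 in two places, which makes these methoxy steps the first single-place steps on this aromatic carbon beyond the scatter.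

Open, as far as these compounds go, is how a compound drawn R at the chain carbon would read in this assay, and what share of each configuration compound 4 holds. Also open, from the compounds shown here alone, is how an amine, a carboxylic acid or a longer alkoxy chain on the same aromatic carbon would compare with methoxy.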